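Adding a benzyl group to compound 2

A few compounds are considered here, and "the series" means these few. Any claim that something is new, unique, unknown or untested is made for them only; others in the source may bear on it.

Two related compounds have been measured in a functional assay on A549 cells (Homo sapiens) for cytotoxicity, read by MTT assay, with a stated time of 72 h; on this read-out lower numbers stand for stronger inhibition and higher numbers for weaker inhibition. Compound 1 (`CN(C)Cc1ccc2nc(NC(=O)N/N=C/c3cn(Cc4ccccc4)c4ccccc34)sc2c1`) gives 2900 nM, and compound 2 (`CCN(CC)Cc1ccc2nc(NC(=O)N/N=C/c3c[nH]c4ccccc34)sc2c1`) gives 3300 nM, so compound 2 stands level with compound 1 within the usual scatter of such measurements.

Compound 3 (`CCN(CC)Cc1ccc2nc(NC(=O)N/N=C/c3cn(Cc4ccccc4)c4ccccc34)sc2c1`) is compound 2 with a single change: benzyl in place of hydrogen on an aromatic nitrogen. Among the measured compounds shown here, no measured pair shows this change alone, so its size cannot be read directly from the data. Compound 1 also carries a benzyl on that nitrogen and gives 2900 nM, which offers no hint of a large shift. In this assay, no step beyond the scatter is therefore expected, in either direction. The estimated change is a 1.2-fold lower number from compound 2 to compound 3 (0.07 log units; within the scatter). Compound 3 is expected at about 2800 nM, with an estimated range from 1000 nM to 7000 nM.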

Compound 3, half-maximal inhibitory concentration: 3330 nM
The estimate for compound 3 lay 1.2-fold (0.08 log units) below the measured number; low and high end bracket the measured number.
By their numbers in this assay, from the lowest: compounds 1, 2 and 3 (each within the scatter of the next).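

In this assay, benzyl in place of hydrogen on the aromatic nitrogen now has a directly measured size, a 1.0-fold higher number from compound 2 to compound 3 (0.00 log units; within the scatter), so adding these 7 heavy atoms at this position leaves the number level with that of the compound without them. The second new pair, with diethylamino in place of dimethylamino on the saturated chain carbon, gives a 1.1-fold higher number from compound 1 to compound 3 (0.06 log units; within the scatter), so this change also stays within the scatter when benzyl is present. Nothing measured here offers a reason for either result.

Going by these compounds, it remains open whether a different group on that nitrogen, such as methyl, a longer chain ending in an amine, or a chain ending in a carboxylic acid, would shift the number. On these data alone, it is also open whether morpholine in place of diethylamino would do so.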